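This account rests on a few compounds, and the source may have more. Where it says the series, first, only, none or still open, it means among the compounds named here.

Measured in a physicochemical assay for lipophilicity, using the shake flask method, measured as octanol-water partition, at pH 7.4; on this read-out higher numbers stand for higher lipophilicity and lower numbers for lower lipophilicity:
Compound 1, `CCCN(CCC)CCCOc1ccc(C(=O)/C=C/c2ccccc2)cc1`, gives 1.91.
Compound 2, `CCCCN(CCCC)CCCOc1ccc(C(=O)/C=C/c2ccccc2)cc1`, gives 2.06.
Compound 3, `CCCN(CCC)CCCCOc1ccc(C(=O)/C=C/c2ccccc2)cc1`, gives 1.95.

Among these three numbers compound 3 stands second highest. Its nearest neighbour is compound 1, with a number 0.04 log units higher from compound 1 to compound 3 (within the scatter), and its furthest is compound 2, with a number 0.11 log units lower from compound 2 to compound 3 (within the scatter); both of these steps lie within the scatter, so the three measured compounds cannot be set apart from one another in this assay.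

Compound 4, `CCCCN(CCCC)CCCCOc1ccc(C(=O)/C=C/c2ccccc2)cc1`, differs from compound 3 in one place: dibutylamino in place of dipropylamino on a saturated chain carbon, four bonds along the chain from an oxygen on an aromatic ring. Among the compounds with values here, the measured step that bears directly on this change is the one between compound 1 and compound 2, where the same exchange of groups sits at a saturated chain carbon three bonds along the chain from the oxygen on the aromatic ring: a number 0.15 log units higher from compound 1 to compound 2 (within the scatter). That step was small and within the scatter. There is no reason in the data to expect the exchange to behave differently one bond further out, so the expected step is a number 0.15 log units higher from compound 3 to compound 4 (within the scatter), a slight rise that stays within the scatter. Compound 4 is therefore estimated at 2.1, with a range from 1.8 to 2.4.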

Compound 4, partition coefficient: 2.09
Compound 4: middle estimate off by 0.01 log units, on the high side, within the range that was stated.
By their numbers in this assay, from the lowest: compounds 1, 3, 2 and 4 (each within the scatter of the next).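

In this assay, dibutylamino in place of dipropylamino on a saturated chain carbon, four bonds along the chain from an oxygen on an aromatic ring, gives a number 0.14 log units higher from compound 3 to compound 4 (within the scatter) and so reads much the same as a number 0.15 log units higher from compound 1 to compound 2 (within the scatter) at the place three bonds along the chain, which means the exchange has now been seen at two places and stays small at both. The other new comparisons are just as small: (dibutylamino)methyl in place of dibutylamino gives a number 0.03 log units higher from compound 2 to compound 4 (within the scatter) and, with both changes taken at once, (dibutylamino)methyl in place of dipropylamino gives a number 0.18 log units higher from compound 1 to compound 4 (within the scatter), so the four compounds cannot be set apart in this read-out. No measurement shown here accounts for the size of these steps.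

On these data alone, what happens with a much shorter or longer group on the nitrogen, such as dimethylamino or dihexylamino, or with a still longer chain carrying the amine, remains open. So does the outcome for a primary amine or a carboxylic acid at the end of the chain, since all four compounds shown carry a tertiary amine there.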